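The source may hold more compounds than are shown below. What is called first, only, known or untested is meant among the compounds shown, and "the series" means these compounds.

Values in an ADME assay on TZM cells (Homo sapiens) for cytotoxicity, read by XTT assay, with a stated time of 4 days; a lower number here means that less compound is tolerated, a higher number that more compound is tolerated:
Compound 1 `Cc1cc(C#N)cc(C)c1Oc1ccc(N)c(Nc2ccc(C#N)cc2)n1`: 8980 nM
Compound 2 `Cc1cc(Br)cc(C)c1Oc1ccc([N+](=O)[O-])c(Nc2ccc(C#N)cc2)n1`: > 45600 nM (a limit)
Compound 3 `Cc1cc(/C=C/C#N)cc(C)c1Oc1ccc([N+](=O)[O-])c(Nc2ccc(C#N)cc2)n1`: > 48600 nM (a limit)

Compound 2 has no exact position on this scale: its > 45600 nM is a limit, not a number. Compound 3 also has only a limit, > 48600 nM. Within the data shown here, the one measured step, a step that the two limits leave unreadable from compound 2 to compound 3, therefore offers no size to build on.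

Compound 4 `Cc1cc(Br)cc(C)c1Oc1ccc(N)c(Nc2ccc(C#N)cc2)n1` is compound 2 with a single change, amino in place of nitro on an aromatic carbon. The nearest guide is compound 1, which also carries the amino group and has a measured 8980 nM. On that basis, the expected step is an at least 4.1-fold lower number from compound 2 to compound 4 (0.61 log units; beyond the scatter), downward in this assay, meaning that less compound is tolerated. For compound 4 the estimate is 11000 nM, with an expected range of 4000 nM to 35000 nM.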

Compound 4, half-maximal cytotoxic concentration: 15500 nM
Compound 4: the middle estimate sits 1.4-fold (0.15 log units) below what was measured, within the range that was stated.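

In this assay, amino in place of nitro gives an at least 2.9-fold lower number from compound 2 to compound 4 (0.46 log units; beyond the scatter) and so marks this position as one where the change is visible beyond the scatter. That size is only a floor, because compound 2 has a limit rather than a number: the limit of > 45600 nM in this assay, at which 1 of the 4 values shown sits. With amino kept, bromo in place of cyano gives a 1.7-fold higher number from compound 1 to compound 4 (0.24 log units; within the scatter) and so shows no real change at that other site.

The step from compound 2 to compound 3 joins two limits and cannot be read. From the compounds shown here alone, how a methylamino or acetamido group at the amino position would compare remains open.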